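This account rests on a few compounds, and the source may have more. Where it says the series, first, only, none or still open, it means among the compounds named here.

Compound 1, `CCOc1nc(N)nc2c1ncn2/C=C1/CC1(CO)CO`, is tested in an ADME assay on CCRF-HSB-2 cells (Homo sapiens) for cytotoxicity, with a stated time of 7 days; a lower number here means that less compound is tolerated, a higher number that more compound is tolerated. In this assay compound 1 gives only a limit, > 20000 nM, and not a number. Compound 2, `Nc1nc(N2CCCC2)c2ncn(/C=C3/CC3(CO)CO)c2n1`, likewise gives in this assay only a limit, > 20000 nM. Compound 3, `CCCCOc1nc(N)nc2c1ncn2/C=C1/CC1(CO)CO`, also stands in this assay at a limit, > 20000 nM. The three steps among them are therefore unreadable: a step that the two limits leave unreadable from compound 1 to compound 2, a step that the two limits leave unreadable from compound 1 to compound 3 and a step that the two limits leave unreadable from compound 2 to compound 3. What unites all three is the limit of > 20000 nM in this assay, at which 3 of the 3 values shown sit.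

The account follows the step from compound 1 to compound 4, `CCCCNc1nc(N)nc2c1ncn2/C=C1/CC1(CO)CO`, which is still to be measured in this assay. The change is butylamino in place of ethoxy on an aromatic carbon. For the measured compounds named here, the steps that bear on it, from compound 1 to compound 2 and from compound 1 to compound 3, each replace the ethoxy on an aromatic carbon with another group, and both are unreadable because each value sits at the limit of > 20000 nM in this assay, at which 3 of the 3 values shown sit. Accordingly no step beyond the scatter is expected in this assay, and the step is estimated as a step that the limit leaves unreadable from compound 1 to compound 4. Compound 4 is expected to give about 30000 nM, within 15000 nM to 100000 nM, most probably again as a limit only.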

Compound 4, half-maximal cytotoxic concentration: > 20000 nM
Compound 4: a limit, no number; the forecaster's own chance of this, stated with the estimate: 85%; the middle value lies beyond the limit too.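

In this assay compound 4 also gives only a limit, > 20000 nM. The steps linking compound 4 with compound 1, compound 2 and compound 3 therefore cannot be read: the limit of > 20000 nM in this assay, at which 4 of the 4 values shown sit.

The compounds shown leave open at what concentration any of them becomes cytotoxic, and whether the group on the aromatic carbon alters that concentration.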